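A Chloro-to-Bromo Swap at the Assay Limit

The source may report more compounds than this note shows. Statements on the series, on what has been measured and on what is new or still open speak of the compounds shown alone.

In a functional assay on HOS cells (Homo sapiens) for antiproliferative activity, with a stated time of 72 h (a higher number here means a weaker inhibitor, a lower number a stronger inhibitor), compound 1 (`OC[C@H]1O[C@@H](n2cnc3c(NCc4ccccc4F)ncnc32)[C@H](O)[C@@H]1O`) gives > 166000 nM, which is a limit and not a number. Compound 2 (`OC[C@H]1O[C@@H](n2cnc3c(NCc4ccc(Cl)cc4)ncnc32)[C@H](O)[C@@H]1O`) gives > 166000 nM, which is also a limit. The picture so far is the limit of > 166000 nM in this assay, at which 2 of the 2 values shown sit. Going by the values given here, the only measured step is a step that the two limits leave unreadable from compound 1 to compound 2, so it offers no size to carry forward.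

Compound 3 (`OC[C@H]1O[C@@H](n2cnc3c(NCc4ccc(Br)cc4)ncnc32)[C@H](O)[C@@H]1O`) has bromo in place of chloro on an aromatic carbon, para to a large group: bromo in place of chloro on an aromatic carbon. With no readable step to draw on, no step beyond the scatter is expected in this assay, in either direction. That expectation rests on compound 2, whose reading of > 166000 nM is a limit. The expected change is a step that the limit leaves unreadable from compound 2 to compound 3. Compound 3 is estimated at 170000 nM, with an expected range from 60000 nM to 300000 nM, and it may well again be reported only as a limit.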

Compound 3, half-maximal inhibitory concentration: > 166000 nM
Compound 3 was reported as a limit; the forecaster's own chance of this, stated with the estimate: 75%; the middle value does not contradict the limit.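

Going by these compounds alone, compound 3 is reported only as a limit, as are compound 1 and compound 2, so no step among the three can be read: the limit of > 166000 nM in this assay, at which 3 of the 3 values shown sit.
What stays open is where any of these compounds would fall in this assay as an actual number, and so whether swapping these groups changes anything.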